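The source may report more compounds than this note shows. Statements on the series, on what has been measured and on what is new or still open speak of the compounds shown alone.

Working notes on the series.

Compound 1 `COc1ccc(C2=NN(C(=O)C3COc4ccccc4O3)C(c3cccc(F)c3)C2)cc1` carries a methoxy group and in a functional assay on WM 266-4 cells (Homo sapiens) for inhibition, read by MTT assay, with a stated time of 24 h (a higher number here means a weaker inhibitor of growth, a lower number a stronger inhibitor of growth), compound 1 gives 6720 nM. Compound 2 `O=C(C1COc2ccccc2O1)N1N=C(c2ccccc2)CC1c1cccc(F)c1` differs from compound 1 only by hydrogen in place of methoxy on an aromatic carbon and in this assay compound 2 gives 1450 nM; the step is a 4.6-fold lower number from compound 1 to compound 2 (0.67 log units; beyond the scatter). Compound 3 `COc1ccc(C2CC(c3ccc(Br)cc3)=NN2C(=O)c2ccc3c(c2)OCCO3)cc1` is built on a different core, and the difference between the core of compound 1 and the core of compound 3 is not broken down here. In this assay compound 3 gives 5680 nM, a number that sits within the scatter of compound 1 and beyond the scatter from compound 2.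

Compound 4 `O=C(c1ccc2c(c1)OCCO2)N1N=C(c2ccc(Br)cc2)CC1c1ccccc1` has not yet been measured. It differs from compound 3 by hydrogen in place of methoxy on an aromatic carbon. This is the same change as the one from compound 1 to compound 2, at the same kind of place on the ring, and it occurs twice among these compounds. Within the data shown here, only a single measured instance of it exists, and that instance was made on another core, so the transfer to compound 3 is uncertain.

The working expectation is that compound 4 gives about 1500 nM in this assay. The expected range is taken wide for compound 4, which is estimated to lie between 500 nM and 4500 nM. Among the measured compounds shown here, the expected step for compound 4 is a 3.8-fold lower number from compound 3 to compound 4 (0.58 log units; beyond the scatter), resting on the single earlier instance, a 4.6-fold lower number from compound 1 to compound 2 (0.67 log units; beyond the scatter), with some allowance for the change of core.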

Compound 4, concentration for 50% growth inhibition: 1790 nM
The estimate for compound 4 lay 1.2-fold (0.08 log units) below the measured number; measured number inside the range.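

In this assay, hydrogen in place of methoxy gives a 3.2-fold lower number from compound 3 to compound 4 (0.50 log units; beyond the scatter), and this step can be set directly beside the earlier one on the other core: the same change on two cores in this assay, a 4.6-fold lower number (0.67 log units; beyond the scatter) from compound 1 to compound 2 and a 3.2-fold lower number (0.50 log units; beyond the scatter) from compound 3 to compound 4, 1.5-fold (0.16 log units) apart, within the scatter of two such steps. Among these compounds, on these two cores, then, the change from 4-methoxyphenyl to phenyl carries over in direction and, within the scatter, in size, with a lower number each time and no compound pair going against it. Two pairs in one cell line and one read-out do not establish a rule for other cores in the series, and they do not show why the number falls or whether the step would hold in another assay.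

The compounds shown leave open whether the lower number depends on removing the methoxy group as such or whether other groups at the same place, such as a hydroxyl, a fluorine, an amine, a carboxylic acid or a longer chain such as ethoxy, would give a similar step. Among the compounds shown here, they also leave open how much of the remaining difference between the two cores comes from each of the places in which those cores differ, since no pair here separates those places one at a time.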